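One aromatic group swapped in a low-scoring compound

This account rests on a few compounds, and the source may have more. Where it says the series, first, only, none or still open, it means among the compounds named here.

In a functional assay on MCF7 cells (Homo sapiens) for inhibition, read by MTT assay, with a stated time of 48 h, tested at 10 uM (on this read-out higher numbers stand for more inhibition of growth at the one concentration tested and lower numbers for less inhibition of growth), compound 3 `Cc1oc2c([C@H]3CCN(C)C[C@H]3O)c(O)cc(O)c2c(=O)c1C(O)c1cccc(Cl)c1` gives 5%, the lowest of three numbers, while compound 1 `Cc1cc(=O)c2c(O)c(CN3CCN(C(=O)OC(C)(C)C)CC3)c(O)c([C@H]3CCN(C)C[C@H]3O)c2o1` gives 16% and compound 2 `CCOC(=O)N1CCN(Cc2c(O)c([C@H]3CCN(C)C[C@H]3O)c3oc(C)cc(=O)c3c2O)CC1` gives 31%. Compound 4 `COc1ccc(C(O)c2c(C)oc3c([C@H]4CCN(C)C[C@H]4O)c(O)cc(O)c3c2=O)cc1Br` is still unmeasured. It carries 3-bromo-4-methoxyphenyl in place of 3-chlorophenyl on a saturated chain carbon bound to an aromatic carbon and an oxygen on a saturated carbon. Within the data shown here, the only measured step, a number 15 percentage points higher from compound 1 to compound 2 (beyond the scatter), is modest and swaps tert-butyl for ethyl, a different change in a different pair, so it offers only loose guidance. The estimate is a number 3 percentage points higher from compound 3 to compound 4 (within the scatter), so no step beyond the scatter is expected. In this assay, the estimate for compound 4 is 8%, with an expected range from 0% to 22%.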

Compound 4, percent growth inhibition at one concentration: 41%
For compound 4 the middle estimate is 33 percentage points below the measured one; measured number outside the range, above it.
By their numbers in this assay, from the lowest: compound 3; then compound 1; then compounds 2 and 4 (each within the scatter of the next).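

In this assay, among these compounds, the swap of 3-chlorophenyl for 3-bromo-4-methoxyphenyl gives a number 36 percentage points higher from compound 3 to compound 4 (beyond the scatter) at this position, so changing the aromatic group here can move the read-out strongly, which no earlier pair showed. The swap changes the halogen and adds a methoxy at once, and this single pair cannot separate the two. No measurement at hand explains the rise. Still open, going by these compounds, is whether the bromine or the methoxy carries the step. Also open, on these data alone, is what an amine or a carboxylic acid on this aromatic ring would do.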